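Ring Expansion in the Amine Tail of a GIP Receptor Agonist

This account rests on a few compounds, and the source may have more. Where it says the series, first, only, none or still open, it means among the compounds named here.

Measured so far:
Compound 1 `CC1(OC(=O)N2CCC(O[C@H]3CC[C@H](Oc4cnc(S(C)(=O)=O)cn4)CC3)CC2)CC1` gives 138 nM in a functional assay on isolated protein for agonist activity at Glucose-dependent insulinotropic receptor (Rattus norvegicus), read by HTRF and cAMP accumulation; a higher number here means that more compound is needed for the effect, a lower number that less compound is needed.
Compound 2 `CS(=O)(=O)c1cnc(O[C@H]2CC[C@H](OC3CCN(CC4(C(F)(F)F)CC4)CC3)CC2)cn1` gives 163 nM in this assay.

These two compounds share one core and differ only in the group carried by the amine nitrogen in a ring. Among the measured compounds shown here, the single step between them, a 1.2-fold higher number from compound 1 to compound 2 (0.07 log units; within the scatter), shows that exchanging that group left the read-out essentially unchanged. Compound 2 stands as the higher of the two numbers, but its separation from compound 1 is within the scatter, so the two cannot be ordered.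

Compound 3 `CS(=O)(=O)c1cnc(O[C@H]2CC[C@H](OC3CCN(CC4(C(F)(F)F)CCC4)CC3)CC2)cn1` is not yet measured. It differs from compound 2 by 1-(trifluoromethyl)cyclobutyl in place of 1-(trifluoromethyl)cyclopropyl on a saturated chain carbon bound to an amine nitrogen in a ring. For the measured compounds named here, no measured step tests this kind of ring growth, and the one step available, from a carbamate to a trifluoromethyl-cyclopropyl tail, bears on the same position only loosely. With the tail already tolerated in compound 2, a small change there is expected to move the number little: the estimated step is a 1.0-fold higher number from compound 2 to compound 3 (0.02 log units; within the scatter), within the scatter. Compound 3 is therefore expected to give about 170 nM in this assay, with a range from 70 nM to 420 nM.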

Compound 3, half-maximal effective concentration: 80 nM
Compound 3: the middle estimate sits 2.1-fold (0.33 log units) above what was measured; measured number inside the range.
By their numbers in this assay, from the lowest: compounds 3, 1 and 2 (each within the scatter of the next, the first and the last beyond it).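

Growing the three-membered ring to a four-membered one, on a saturated chain carbon bound to an amine nitrogen in a ring, is the first change in this set to move the number beyond the scatter. In this assay this change gives a 2.0-fold lower number from compound 2 to compound 3 (0.31 log units; beyond the scatter) and so counts as a modest gain, with less compound needed for the effect. Set against the carbamate tail, the new tail gives a 1.7-fold lower number from compound 1 to compound 3 (0.24 log units; within the scatter) and so cannot be ordered relative to compound 1, which leaves compound 2 and compound 3 as the only pair clearly separated; no measurement shown here bears on what lies behind the ring-size step.

Among the compounds shown here, with only two ring sizes on this tail, it remains open whether 1-(trifluoromethyl)cyclopentyl in the same place would continue this trend or reverse it. On these data alone, it is also open how much the trifluoromethyl group itself contributes, a question that 1-methylcyclobutyl in place of 1-(trifluoromethyl)cyclobutyl would address.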